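Dimethylamino Replacing the Chlorobenzylamine on the Shared Core

The source may report more compounds than this note shows. Statements on the series, on what has been measured and on what is new or still open speak of the compounds shown alone.

Measured in a functional assay on DLD-1 cells (Homo sapiens) for inhibition, read by MTT assay, with a stated time of 72 h; on this read-out higher numbers stand for weaker inhibition and lower numbers for stronger inhibition:
Compound 1 `COc1ccc(CNCc2c(OC)cc(Oc3cccc(Nc4ccccc4)c3)cc2OC)cc1`: 1910 nM
Compound 2 `COc1cc(Oc2cccc(Nc3ccccc3)c2)cc(OC)c1CN[C@H](C)c1ccccc1`: 8570 nM
Compound 3 `COc1cc(Oc2cccc(Nc3ccccc3)c2)cc(OC)c1CNCc1ccc(Cl)cc1`: 3740 nM

Compound 3 stands within the scatter of one neighbour and clear of the other: a 2.0-fold higher number from compound 1 to compound 3 (0.29 log units; within the scatter), and a 2.3-fold lower number from compound 2 to compound 3 (0.36 log units; beyond the scatter). The next compound, compound 4 `COc1cc(Oc2cccc(Nc3ccccc3)c2)cc(OC)c1CN(C)C`, has not yet been measured. Its change is dimethylamino in place of (4-chlorobenzyl)amino on a saturated chain carbon bound to an aromatic carbon, dimethylamino in place of (4-chlorobenzyl)amino. The closest evidence comes from changes on the same amine nitrogen: a 4.5-fold higher number from compound 1 to compound 2 (0.65 log units; beyond the scatter), and the step from compound 2 already shown. As far as these compounds go, neither of these involves dimethylamino, so the direction stays open, and no shift beyond the scatter is expected in this assay. The expected step is a 1.3-fold higher number from compound 3 to compound 4 (0.13 log units; within the scatter). For compound 4 the estimated value is 5000 nM, with a range from 1500 nM to 16000 nM.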

Compound 4, half-maximal inhibitory concentration: > 20000 nM
Compound 4: no number, only a limit; the forecaster's own chance of this, stated with the estimate: 10%; middle value at least 4.0-fold (0.60 log units) away from the limit.
By their numbers in this assay, from the lowest: compounds 1 and 3 (each within the scatter of the next); then compound 2. At a limit, above all of these: compound 4.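

In this assay compound 4 gives only a limit and not a number: the limit of > 20000 nM in this assay, at which 1 of the 4 values shown sits. Dimethylamino on this saturated chain carbon therefore separates clearly from all three amines that carry an aromatic ring, with an at least 5.3-fold higher number from compound 3 to compound 4 (0.72 log units; beyond the scatter), an at least 2.3-fold higher number from compound 2 to compound 4 (0.36 log units; beyond the scatter) and an at least 10-fold higher number from compound 1 to compound 4 (1.01 log units; beyond the scatter). Among the compounds shown, only the amine with no ring and no hydrogen-bond donor reaches the limit.

The compounds shown do not separate the loss of the ring from the loss of the amine hydrogen. (Cyclohexylmethyl)amino and N-methylbenzylamino on the same carbon would each remove only one of these.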